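Swapping the methoxypyridine group of compound 1

The source may hold more compounds than are shown below. What is called first, only, known or untested is meant among the compounds shown, and "the series" means these compounds.

In an ADME assay on microsomes from liver (Homo sapiens) for metabolic stability (on this read-out higher numbers stand for a longer-lived compound and lower numbers for a shorter-lived compound), compound 1 `COc1cc(OCc2cccc(-c3ccc(OC)nc3)c2)c2cc(-c3cn4nc(OC)sc4n3)oc2c1` gives 0.733 h. Compound 2 `COc1cc(OCc2csc(-c3ccc(S(C)(=O)=O)cc3)n2)c2cc(-c3cn4nc(OC)sc4n3)oc2c1` gives 1.22 h, within the scatter of compound 1. Compound 3 `COc1cc(OCc2csc(-c3ccc(C(=O)O)cc3)n2)c2cc(-c3cn4nc(OC)sc4n3)oc2c1` reads > 2 h, which is a limit of the assay and not a number. Compound 4 `COc1ccc(-c2cccc(COc3cc(OC)cc4oc(-c5cn6nc(OC)sc6n5)cc34)c2)nc1` has the same atoms as compound 1, joined differently: 5-methoxypyridin-2-yl in place of 6-methoxypyridin-3-yl on an aromatic carbon. Here 5-methoxypyridin-2-yl stands in place of 6-methoxypyridin-3-yl on an aromatic carbon. Going by the values given here, the only measured step, an at least 1.6-fold higher number from compound 2 to compound 3 (0.21 log units; that floor lies within the scatter), is carboxy in place of methylsulfonyl, another kind of change that does not speak to this exchange. No shift beyond the scatter is therefore expected, and the estimated step is a 1.0-fold higher number from compound 1 to compound 4 (0.01 log units; within the scatter). For compound 4 the estimate in this assay is 0.75 h, with an expected range from 0.4 h to 1.4 h.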

Compound 4, half-life: 0.767 h
Compound 4: middle estimate off by 1.0-fold (0.01 log units), on the low side; the range from low to high includes it.
By their numbers in this assay, from the lowest: compounds 1, 4 and 2 (each within the scatter of the next). At a limit, above all of these: compound 3.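

In this assay, 5-methoxypyridin-2-yl in place of 6-methoxypyridin-3-yl gives a 1.0-fold higher number from compound 1 to compound 4 (0.02 log units; within the scatter). At this place, meta to a large group, joining the same atoms differently therefore causes no shift beyond the scatter. Going by these compounds alone, no earlier pair of compounds differed only in this group, so this is the first direct reading of the exchange. Nothing shown bears on why the two pyridine groups read alike:.

Still open, from the compounds shown here alone, is whether an ethoxy group or an amine in place of the methoxy on either pyridine would change the half-life beyond the scatter. A plain phenyl ring at this place is equally untested by the compounds shown.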